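The source may report more compounds than this note shows. Statements on the series, on what has been measured and on what is new or still open speak of the compounds shown alone.

Of the compounds shown here, two of this set have been measured in an assay on isolated protein for inhibition of high affinity 3',5'-cyclic-AMP phosphodiesterase 7A (Homo sapiens), read by scintillation proximity assay and cAMP accumulation, with a stated time of 20 min, tested at 10 uM; on this read-out higher numbers stand for more inhibition at the one concentration tested (going by the name of the read-out) and lower numbers for less inhibition. Compound 1 `COc1ccc(Cn2c(=O)[nH]c3ncccc3c2=O)cc1` gives 8% in this assay. Compound 2 `O=c1c2cccnc2[nH]c(=S)n1-c1ccccc1` gives -3.1% in this assay, the lowest of the two numbers, with compound 1 standing higher by an amount beyond the usual scatter. Compound 3 `O=c1c2cccnc2[nH]c(=S)n1-c1cccc(Br)c1` has not yet been measured; it differs from compound 2 by bromo in place of hydrogen on an aromatic carbon. Among the compounds with values here, no step between measured compounds is known here, so nothing shows how a bromo acts in this setting, and the step is expected to be small, within the scatter, in either direction. For compound 3 in this assay the estimated value is 3%, with a range from -10% to 18%. This amounts to an expected step of a number 6.1 percentage points higher from compound 2 to compound 3 (within the scatter).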

Compound 3, a percentage reported as inhibition, at one concentration (the size of the read-out at that concentration, not a potency): 12.8%
Beside the measured number, compound 3's estimate is 9.8 percentage points below it; measured number inside the range.
By their numbers in this assay, from the lowest: compound 2; then compounds 1 and 3 (each within the scatter of the next).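

Within the data shown here, replacing hydrogen with bromo, on the carbon-only aromatic ring and meta to a large group, gives the first measured step at this position: in this assay the change brings a number 15.9 percentage points higher from compound 2 to compound 3 (beyond the scatter) and so shows that this position can respond to substitution, if only modestly. Nothing available here explains the rise.

Still open, as far as these compounds go, is whether a smaller chloro or fluoro, or a methoxy or an amine, would act the same way at this place. The compounds shown also leave open whether bromo would give a similar step elsewhere on the ring.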